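Phenyl in Place of Phenoxy on the Carbonyl Carbon

This account rests on a few compounds, and the source may have more. Where it says the series, first, only, none or still open, it means among the compounds named here.

Compound 1: `COc1ccc(S(=O)(=O)N2CCc3cccc(NC(=O)Oc4ccccc4)c32)cc1`, > 10000 nM
Compound 2: `COc1ccc(S(=O)(=O)N2CCc3cccc(NC(=O)c4ccc(F)cc4)c32)cc1`, 93 nM

Of the compounds shown here, two sharing one core have been measured in a functional assay on KB cells (Homo sapiens) for cytotoxicity; on this read-out higher numbers stand for weaker inhibition and lower numbers for stronger inhibition. For compound 1 the result is only a limit, (the limit of > 10000 nM in this assay, at which 1 of the 2 values shown sits). Compound 2 gives 93 nM. Among the compounds with values here, the single measured step, an at least 100-fold lower number from compound 1 to compound 2 (2.03 log units; beyond the scatter), is large and beyond the scatter.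

Compound 3, `COc1ccc(S(=O)(=O)N2CCc3cccc(NC(=O)c4ccccc4)c32)cc1`, is not yet measured. It differs from compound 1 in one place: phenyl in place of phenoxy on a carbonyl carbon. This change runs parallel to the measured step: both remove phenoxy from the carbonyl carbon and put an aromatic ring of carbon only in its place, the measured one carrying a fluorine, this one not. The large size of an at least 100-fold lower number from compound 1 to compound 2 (2.03 log units; beyond the scatter) therefore points to an expected step of similar size in the same direction, toward a lower number. Compound 3 is expected at 150 nM, within 40 nM to 600 nM, which corresponds to an expected at least 66-fold lower number from compound 1 to compound 3 (1.82 log units; beyond the scatter).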

Compound 3, half-maximal inhibitory concentration: 297 nM
Estimate against measurement, compound 3: 2.0-fold (0.30 log units) below, within the range that was stated.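

The change from phenoxy to phenyl on the carbonyl carbon does not need the fluorine to work: in this assay, the plain benzoyl group gives an at least 33-fold lower number from compound 1 to compound 3 (1.52 log units; beyond the scatter). The fluoro group still counts on its own, though less dramatically, since hydrogen in its place gives a 3.2-fold higher number from compound 2 to compound 3 (0.50 log units; beyond the scatter). The value of compound 1 is a limit and not a number, so the first of these steps has no known upper end: the limit of > 10000 nM in this assay, at which 1 of the 3 values shown sits.

From the compounds shown here alone, whether chloro or methoxy in place of the fluoro group would lower the number further remains open. So does whether a benzyl group, which keeps a ring but has carbon where phenoxy has oxygen, or a cyclohexyl ring or longer chain on the carbonyl carbon, would hold the lower numbers.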